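The compounds below may be only part of what the source reports. "The series", "measured", "known", "first", "only" and "open" are said of these compounds alone.

Within the data shown here, in a functional assay (brain) for inhibition, with Rattus norvegicus as the target (a lower number here means a stronger inhibitor, a higher number a weaker inhibitor), compound 2 `COc1cc2c(cc1O)C(=O)CC(C(=O)Nc1ccccc1)O2` gives 293000 nM, the higher of the two true numbers so far. Compound 3 `COc1cc2c(cc1O)CCC(C(=O)Nc1ccc([N+](=O)[O-])cc1)O2` gives 3800 nM, a much lower number, and the gap between these two values lies beyond the scatter. Compound 1 `COc1cc2c(cc1O)C(=O)CC(C(=O)O)O2` reaches only a limit of the assay, > 300000 nM.

The next compound, compound 4 `COc1cc2c(cc1O)C(=O)CC(C(=O)NCc1ccccc1)O2`, differs from compound 2 in one group: benzyl in place of phenyl on an amide-type nitrogen. In words, this is benzyl in place of phenyl on an amide-type nitrogen, or anilino to benzylamino.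

Among the measured compounds shown here, only one measured step touches this amide group: an at least 1.0-fold lower number from compound 1 to compound 2 (0.01 log units; that floor lies within the scatter). That step is anilino in place of hydroxy on a carbonyl carbon, and it gives only a floor, not a true size. For the measured compounds named here, no measured step shows what benzyl does here, so no step beyond the scatter is expected, and the starting point stays compound 2 at 293000 nM. The expected change is a 1.5-fold lower number from compound 2 to compound 4 (0.17 log units; within the scatter), which would be too small to read as a real difference. A weak result could also end at the limit of > 300000 nM in this assay, at which 1 of the 3 values shown sits, so a limit in place of a number is a real possibility. For compound 4 the estimated value is 200000 nM, with an expected range from 70000 nM to 450000 nM.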

Compound 4, half-maximal inhibitory concentration: > 300000 nM
Compound 4: only a limit was reported; the forecaster's own chance of this, stated with the estimate: 35%; at least 1.5-fold (0.17 log units) between middle value and limit.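

Swapping phenyl for benzyl on the amide-type nitrogen gives no sign of a stronger inhibitor in this assay, and the only readable result is an at least 1.0-fold higher number from compound 2 to compound 4 (0.01 log units; that floor lies within the scatter). This is a floor rather than a true size, so the benzyl group may leave the inhibition unchanged or may weaken it, and the data cannot separate these two outcomes. Compound 4 ends at a limit rather than a number, as compound 1 does, so the step joining those two cannot be read, and this kind of result now makes up a large share of the series: the limit of > 300000 nM in this assay, at which 2 of the 4 values shown sit.

Compound 3, at 3800 nM, differs from compound 2 in more than one place, so these compounds do not show which of its changes goes with its much lower number. Also open, from the compounds shown here alone, is whether a longer chain such as phenylethyl on the amide nitrogen, or a nitro group on the ring of the benzyl group, would bring the ketone-bearing core of compound 4 down to a true number.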